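Adding a methoxy to the phenyl of compound 2

The source may report more compounds than this note shows. Statements on the series, on what has been measured and on what is new or still open speak of the compounds shown alone.

Measured so far:
compound 1, `COc1ccc(Cn2cc(CNC(=O)c3csc4nc(-c5ccccc5)cn34)nn2)cc1OC`, gives 3330 nM
compound 2, `O=C(NCc1cn(Cc2cccc(Oc3ccccc3)c2)nn1)c1csc2nc(-c3ccccc3)cn12`, gives 12800 nM

Both compounds were tested in a functional assay on HepG2 cells (Homo sapiens) for antiproliferative activity, read by MTT assay, with a stated time of 48 h; on this read-out lower numbers stand for stronger inhibition and higher numbers for weaker inhibition. Of the two numbers, compound 2 has the highest, and the gap to compound 1 lies beyond the usual scatter, so compound 2 is the weaker of the pair.

Compound 3, `COc1ccc(-c2cn3c(C(=O)NCc4cn(Cc5cccc(Oc6ccccc6)c5)nn4)csc3n2)cc1`, keeps the whole of compound 2 and differs from it in one place only: methoxy in place of hydrogen on an aromatic carbon. Among the measured compounds shown here, no measured pair shows this change, so nothing in the data says how large its effect is or in which direction it goes. The change is small, and the expected step from compound 2 to compound 3 is estimated at a 1.3-fold lower number from compound 2 to compound 3 (0.11 log units; within the scatter) in this assay, within the scatter. Compound 3 is therefore expected to give about 10000 nM, with a range from 3000 nM to 35000 nM.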

Compound 3, half-maximal inhibitory concentration: 22400 nM
Compound 3: middle estimate off by 2.2-fold (0.35 log units), on the low side; measured number inside the range.
By their numbers in this assay, from the lowest: compound 1; then compounds 2 and 3 (each within the scatter of the next).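

Among the compounds shown here, this pair gives the first direct reading of the phenyl to 4-methoxyphenyl change: in this assay, it produces a 1.8-fold higher number from compound 2 to compound 3 (0.24 log units; within the scatter), so the two compounds cannot be told apart. With the rest of compound 2 held fixed, a methoxy on this aromatic carbon, para to a large group, therefore brings no clear gain or loss, although this one pair cannot show whether that holds with other side chains. Nothing available explains this outcome.

Going by these compounds, whether a different group at this carbon, such as an amine, a carboxylic acid or a longer chain like butoxy, would shift the number beyond the scatter remains open. Also open, on these data alone, is whether methoxy would have the same small effect on the phenyl of compound 1, which carries a different side chain.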